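Methoxy count on the ketone-side aryl ring

This account rests on a few compounds, and the source may have more. Where it says the series, first, only, none or still open, it means among the compounds named here.

Measured so far in a functional assay on CCRF-CEM cells (Homo sapiens) for cytotoxicity, read by sulforhodamine B assay, with a stated time of 48 h, tested at 0.01 uM; a higher number here means a weaker effect of the compound at the concentration tested, a lower number a stronger effect:

compound 1 `COc1ccc(-c2cc(/C=C/C(=O)c3cc(OC)c(OC)c(OC)c3)[nH]n2)cc1OC`: 97%
compound 2 `COc1ccc(C(=O)/C=C/c2cc(-c3cc(OC)c(OC)c(OC)c3)n[nH]2)cc1`: 99%
compound 3 `COc1ccc(C(=O)/C=C/c2cc(-c3cc(OC)c(OC)c(OC)c3)n[nH]2)cc1OC`: 95%

All three compounds share the same core and differ only in the methoxy pattern on the aryl ring attached to the carbonyl. The numbers lie close together: compound 3 gives 95%, and its gaps to compound 1 and to compound 2 both fall within the scatter, so no ordering among the three can be read from this assay at the concentration tested.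

Compound 4 `COc1cc(C(=O)/C=C/c2cc(-c3cc(OC)c(OC)c(OC)c3)n[nH]2)cc(OC)c1OC` is not yet measured. From compound 3 it differs by methoxy in place of hydrogen on an aromatic carbon, which completes a trimethoxy pattern on that ring. Among the compounds with values here, the one measured step that bears on this change is the earlier methoxy addition on the same ring, a number 4 percentage points lower from compound 2 to compound 3 (within the scatter), which stayed within the scatter. Within the data shown here, there is no measured step in which a methoxy on this ring moved the read-out beyond the scatter, so a further methoxy is expected to do the same.

For compound 4 in this assay the expected step is a number 1 percentage points higher from compound 3 to compound 4 (within the scatter), that is, none beyond the scatter. The estimate for compound 4 is 96%, with a range from 86% to 103%.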

Compound 4, a percentage reported as activity, at one concentration (the size of the read-out at that concentration, not a potency): 96%
The estimate for compound 4 equals the measured number at the digits printed, within the range that was stated.
By their numbers in this assay, from the lowest: compounds 3, 4, 1 and 2 (each within the scatter of the next).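

In this assay, adding a third methoxy to the ketone-side aryl ring, ortho to a methoxy group and so completing the trimethoxy pattern, gives a number 1 percentage points higher from compound 3 to compound 4 (within the scatter), so the ring's fully substituted form also shows no step beyond the scatter. The same replacement on the other aryl ring of the shared core gives a number 1 percentage points lower from compound 1 to compound 4 (within the scatter), which extends the observation from one ring to both. The change also reads alike across the two comparisons, a point the single earlier step could not show: the same change on two cores in this assay, a number 4 percentage points lower (within the scatter) from compound 2 to compound 3 and a number 1 percentage points lower (within the scatter) from compound 1 to compound 4, 3 percentage points apart, within the scatter of two such steps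

From the compounds shown here alone, the read-out comes from one concentration and is not a potency, and all four compounds lie so close that this concentration cannot separate them, so any effect of the methoxy count that might appear at other concentrations remains unknown. Going by these compounds, it also remains open whether an amine, a carboxylic acid or a longer alkoxy chain in place of a methoxy on either aryl ring would move the read-out beyond the scatter.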